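Cyclohexyl for propyl on the amine of a curcuminoid enamine

This account rests on a few compounds, and the source may have more. Where it says the series, first, only, none or still open, it means among the compounds named here.

Compound 1 `CCCNC(=C\C(=O)/C=C/c1ccc(O)c(OC)c1)/C=C/c1ccc(O)c(OC)c1` was tested in a functional assay on Caco-2 cells (Homo sapiens), read by fluorescence, tested at 1 uM (a lower number here means a stronger effect, a higher number a weaker effect of the compound at the concentration tested), where compound 1 gives 97%. Compound 2 `CCC(C)NC(=C\C(=O)/C=C/c1ccc(O)cc1)/C=C/c1ccc(O)cc1`, which carries a sec-butyl group on the nitrogen and lacks the methoxy groups on both phenols, gives in this assay a reading of 102%. The two values lie within the usual scatter of each other, so compound 1 stands alongside compound 2 rather than apart from it, and neither shows a marked effect at the concentration tested.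

Compound 3 `COc1cc(/C=C/C(=O)/C=C(/C=C/c2ccc(O)c(OC)c2)NC2CCCCC2)ccc1O` is the next compound, not yet measured in this assay. Compared with compound 1 it differs in one place: cyclohexyl in place of propyl on an amine nitrogen. Among the measured compounds shown here, with only two measured compounds, both near full activity and no step between them, there is no evidence on which to expect a change, and the step of no change at the digits printed from compound 1 to compound 3 (within the scatter) is estimated to be none beyond the scatter. Compound 3 is therefore expected to give about 97% in this assay, with a range from 84% to 108%.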

Compound 3, a percentage reported as activity, at one concentration (the size of the read-out at that concentration, not a potency): 88%
Estimate against measurement, compound 3: 9 percentage points above, within the range that was stated.
By their numbers in this assay, from the lowest: compounds 3, 1 and 2 (each within the scatter of the next, the first and the last beyond it).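

Read in this assay, cyclohexyl in place of propyl on the amine nitrogen gives a number 9 percentage points lower from compound 1 to compound 3 (within the scatter) and is the first step that isolates this position. It shows that, in the core of compound 1, a six-membered non-aromatic ring of carbon can replace the open propyl chain with no shift beyond the scatter at the single concentration tested. No measurement is available that could explain this reading.

On these data alone, whether a phenyl ring, a benzyl group, a carboxylic acid or a longer chain carrying a hydroxyl group on the same nitrogen would move the reading beyond the scatter remains open. So does the question of whether any group at this position matters at other concentrations, since a reading at one concentration gives no potency.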